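Exposure of Two Analogues and an Untested Third

The compounds below may be only part of what the source reports. "The series", "measured", "known", "first", "only" and "open" are said of these compounds alone.

Compound 1 `CC(C)(O)c1ccc(-c2cnc3c(n2)N(CC2CCOCC2)C(=O)CN3)cn1` and compound 2 `CO[C@H]1CC[C@H](N2CC(=O)Nc3ncc(-c4ccc(C(C)(C)O)nc4)nc32)CC1` were both examined in an ADME assay on the whole organism for pharmacokinetics, with Rattus norvegicus as the target, at a dose of 5 mg/kg by the oral route; on this read-out lower numbers stand for lower exposure and higher numbers for higher exposure at the dose given. Compound 1 gives 3800 ng.h/mL, the lower of the two exposures, while compound 2 gives 35800 ng.h/mL, a gap beyond the usual scatter. The untested compound 3 `COCCN1C(=O)CNc2ncc(-c3ccc(C(C)(C)O)nc3)nc21` differs from compound 1 in one place: methoxymethyl in place of oxan-4-yl on a saturated chain carbon bound to an amide-type nitrogen in a ring. For the measured compounds named here, no measured pair shows this change, so its effect in this assay is unknown; a shift within the scatter, in either direction, is expected, since compound 1 at 3800 ng.h/mL already sits at the low end of what has been seen. The estimated step is a 1.3-fold lower number from compound 1 to compound 3 (0.10 log units; within the scatter). Compound 3 is expected to give 3000 ng.h/mL, between 1000 ng.h/mL and 9000 ng.h/mL.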

Compound 3, area under the concentration-time curve: 9960 ng.h/mL
Estimate against measurement, compound 3: 3.3-fold (0.52 log units) below; measured number above the stated range.
By their numbers in this assay, from the lowest: compound 1; then compound 3; then compound 2.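

Methoxymethyl in place of oxan-4-yl, on a saturated chain carbon bound to an amide-type nitrogen in a ring, gives a 2.6-fold higher number from compound 1 to compound 3 (0.42 log units; beyond the scatter) in this assay, so this position responds to the change. For this pair, the open chain gives the higher exposure without the six-membered ring, while the hydrogen-bond acceptor count stays the same. Nothing available explains the step.

Going by these compounds, whether the oxygen of the chain matters, or only the absence of the ring, remains open. An all-carbon chain, a longer ether chain or an amine at this place could separate these possibilities.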